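The source may hold more compounds than are shown below. What is called first, only, known or untested is meant among the compounds shown, and "the series" means these compounds.

Three compounds have been measured in an assay on membranes from HEK293 cells for displacement of a labelled ligand from adenosine receptor A2b (Homo sapiens), read by scintillation counting, with a stated time of 30 min; a higher number here means a weaker inhibitor, a lower number a stronger inhibitor:

compound 1 `CCCOC(=O)C1=C(C)NC(=O)NC1c1cccs1` gives 1520 nM
compound 2 `CC1=C(C(=O)OC2CCC2)C(c2cccs2)NC(=O)N1` gives 1090 nM
compound 3 `CC1=C(C(=O)OCC2CC2)C(c2cccs2)NC(=O)N1` gives 1570 nM

All three share the same core and differ only in the ester group. Compound 3 gives the top number of the three, but its separation from the others is slight: the step of a 1.0-fold higher number from compound 1 to compound 3 (0.01 log units; within the scatter) and the step of a 1.4-fold higher number from compound 2 to compound 3 (0.16 log units; within the scatter) are both too small to count as real differences, so the three compounds read as essentially alike in this assay.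

Compound 4 `CC1=C(C(=O)OCC2CCC2)C(c2cccs2)NC(=O)N1` is the next member of the series. The change from compound 3 is cyclobutyl in place of cyclopropyl on a saturated chain carbon bound to an oxygen next to a carbonyl group. The measured steps that bear on this are all changes of the same ester group: a 1.0-fold higher number from compound 1 to compound 3 (0.01 log units; within the scatter), a 1.4-fold lower number from compound 1 to compound 2 (0.14 log units; within the scatter) and a 1.4-fold higher number from compound 2 to compound 3 (0.16 log units; within the scatter). None of them moved the number beyond the scatter, so adding or removing one carbon from a small ring at this position has so far made no visible difference.

The step from compound 3 to compound 4 is therefore expected to be small, a 1.1-fold lower number from compound 3 to compound 4 (0.05 log units; within the scatter), with no clear direction. Compound 4 is expected to give about 1400 nM, with a likely range from 700 nM to 2800 nM.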

Compound 4, inhibition constant: 2840 nM
For compound 4 the middle estimate is 2.0-fold (0.31 log units) below the measured one; measured number above the stated range.
By their numbers in this assay, from the lowest: compounds 2, 1, 3 and 4 (each within the scatter of the next, the first and the last beyond it).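

In this assay, this ester position now shows its first step beyond the scatter (a 2.6-fold higher number from compound 2 to compound 4 (0.42 log units; beyond the scatter)), and the two compounds differ only in the group on the ester oxygen. That step is modest, and the other two steps to compound 4 stay within the scatter (a 1.8-fold higher number from compound 3 to compound 4 (0.26 log units; within the scatter); a 1.9-fold higher number from compound 1 to compound 4 (0.27 log units; within the scatter)), so compound 4 cannot be told apart from compound 3 or compound 1, and only compound 2 and compound 4 separate. The ester group can therefore shift the number measurably, though only slightly across these four compounds, and nothing available here accounts for that shift.

As far as these compounds go, all the groups on the ester oxygen in these compounds are built of carbon only, so it remains open how an amine, a carboxylic acid or a longer chain such as hexyl would read in this place. The shared core is also unchanged throughout, so these compounds say nothing about how a change elsewhere on it would compare with the small movement seen at the ester.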